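Ether-to-alkyl swap at the chain end: compound 4

A few compounds are considered here, and "the series" means these few. Any claim that something is new, unique, unknown or untested is made for them only; others in the source may bear on it.

Compound 1 `CCOCCn1c(N2CCN(C)CC2)nc2ccccc21` gives 10 nM in a functional assay on ileum for inhibition of histamine H1 receptor (Cavia porcellus); a lower number here means a stronger inhibitor, a higher number a weaker inhibitor. Compound 2 `CCCCCCn1c(N2CCN(C)CC2)nc2ccccc21` gives 26 nM, and compound 3 `COCCn1c(N2CCN(C)CC2)nc2ccccc21` gives 13 nM. Compound 3 thus lies between the other two, and both neighbouring steps are within the scatter: a 2.0-fold lower number from compound 2 to compound 3 (0.30 log units; within the scatter) on one side, and on the other the gap to compound 1 is small.

Compound 4 `CC(C)CCn1c(N2CCN(C)CC2)nc2ccccc21` carries the change (isopropyl in place of methoxy on a saturated chain carbon, two bonds along the chain from an aromatic nitrogen). Read one bond further out this is 2-methoxyethyl to isopentyl, so the question is again whether an oxygen in the chain can be replaced by saturated carbon without loss. Among the compounds with values here, two measured steps bear on this. The exchange of ethoxy for butyl gave a 2.6-fold higher number from compound 1 to compound 2 (0.41 log units; beyond the scatter), a modest loss. The reverse exchange, butyl back to methoxy, gave a 2.0-fold lower number from compound 2 to compound 3 (0.30 log units; within the scatter), within the scatter. Both point the same way: the all-carbon chain tends to a somewhat higher number, with a size close to the edge of the scatter.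

For compound 4 a modest rise is therefore expected, a 1.9-fold higher number from compound 3 to compound 4 (0.28 log units; within the scatter), with an estimated value of 25 nM and a range of 10 nM to 60 nM.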

Compound 4, half-maximal inhibitory concentration: 1400 nM
For compound 4 the middle estimate is 56-fold (1.75 log units) below the measured one; the measured number lies above the stated range.
By their numbers in this assay, from the lowest: compounds 1, 3 and 2 (each within the scatter of the next, the first and the last beyond it); then compound 4.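

In this assay, within the data shown here, this position proves far less tolerant than the earlier compounds suggested: a 110-fold higher number from compound 3 to compound 4 (2.03 log units; beyond the scatter), a 140-fold higher number from compound 1 to compound 4 (2.15 log units; beyond the scatter) and a 54-fold higher number from compound 2 to compound 4 (1.73 log units; beyond the scatter), so the isopentyl chain of compound 4 stands well apart from both the ether chains and the other all-carbon chain. Among these compounds, an all-carbon chain does not by itself bring a loss of this size, since compound 2 also has no oxygen in its chain and the step to it is only a 2.6-fold higher number from compound 1 to compound 2 (0.41 log units; beyond the scatter); the large loss is seen only with the isopropyl end, on a saturated chain carbon, two bonds along the chain from an aromatic nitrogen. Nothing among the data shown gives a reason for the size of this step.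

Still open, on these data alone, is whether the loss follows the isopropyl end specifically, which an unbranched propyl, a tert-butyl or a cyclopropyl group at the same place would help to settle. Also open, as far as these compounds go, is how this assay would read for a chain ending in a hydroxyl group or a dimethylamine, which would extend the comparison beyond ether and hydrocarbon ends.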